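The compounds below may be only part of what the source reports. "The series", "measured", "known", "first", "only" and "open" are said of these compounds alone.

Measured so far in a functional assay on Vero cells (Chlorocebus sabaeus) for cytotoxicity; a lower number here means that less compound is tolerated, a higher number that more compound is tolerated:
- compound 1, `CC(C)OC(=O)C(O)Cn1cnc2c(N)ncnc21`, reaching only a limit of the assay: > 400 ug/mL
- compound 2, `COC(=O)C(O)Cn1cnc2c(N)ncnc21`, reaching only a limit of the assay: > 400 ug/mL

Both values are limits, so compound 1 stands at the upper edge of what the assay can report rather than at a measured number. For the measured compounds named here, the step that the two limits leave unreadable from compound 1 to compound 2, methyl in place of isopropyl on an oxygen next to a carbonyl group, therefore cannot be read, and the limit of > 400 ug/mL in this assay, at which 2 of the 2 values shown sit, is the only evidence there is. Compound 3, `Nc1ncnc2c1ncn2CC(O)C(=O)OCc1ccco1`, differs from compound 1 as follows: (furan-2-yl)methyl in place of isopropyl on an oxygen next to a carbonyl group. Going by the values given here, no measured step bears directly on this change, and the single step recorded is unreadable, so no direction beyond the scatter can be predicted; the likeliest outcome is that compound 3 again reaches the limit. The step to compound 3 is thus expected to be a number no higher from compound 1 to compound 3 (the limit leaves the size open). Compound 3 is estimated at 400 ug/mL, with a range from 200 ug/mL to 800 ug/mL.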

Compound 3, minimum cytotoxic concentration: 40 ug/mL
Estimate against measurement, compound 3: 10-fold (1.00 log units) above; the measured number lies below the stated range.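

In this assay, changing the group on an oxygen next to a carbonyl group can clearly move the result away from the limit, which the first two compounds could not show. The change to (furan-2-yl)methyl gives an at least 10-fold lower number from compound 1 to compound 3 (1.00 log units; beyond the scatter), and the comparison with the methyl group gives an at least 10-fold lower number from compound 2 to compound 3 (1.00 log units; beyond the scatter). Both steps start from a limit, so each gives only a minimum size, and isopropyl and methyl themselves cannot be ranked, as the evidence shows: the limit of > 400 ug/mL in this assay, at which 2 of the 3 values shown sit.

Still open, as far as these compounds go, is whether the lower number comes from the furan ring itself or simply from the added atoms; a benzyl group or a longer chain such as hexyl on the same oxygen could separate the two. The compounds shown also give no cause for the change.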